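Pentyl in place of 4-acetylphenyl on an aromatic nitrogen

A few compounds are considered here, and "the series" means these few. Any claim that something is new, unique, unknown or untested is made for them only; others in the source may bear on it.

Compound 1 `CC1(C)CCc2c(ccc(C(=O)/C=C/c3ccc(OCc4cn(-c5ccc(Cl)cc5)nn4)cc3)c2O)O1` - "not active" (no number reported)
Compound 2 `CC(=O)c1ccc(-n2cc(COc3ccc(/C=C/C(=O)c4ccc5c(c4O)CCC(C)(C)O5)cc3)nn2)cc1` - 171000 nM

Both results come from a functional assay on MCF7 cells (Homo sapiens) for antiproliferative activity, read by MTT assay; a lower number here means a stronger inhibitor, a higher number a weaker inhibitor. Within the data shown here, compound 2 at 171000 nM holds the only number so far, since compound 1 was reported without one. The next compound, compound 3 `CCCCCn1cc(COc2ccc(/C=C/C(=O)c3ccc4c(c3O)CCC(C)(C)O4)cc2)nn1`, keeps the shared core and changes a single group: pentyl in place of 4-acetylphenyl on an aromatic nitrogen of a five-membered aromatic ring with 3 nitrogen (pentyl in place of 4-acetylphenyl on an aromatic nitrogen). Among the measured compounds shown here, no measured pair shows what a change at this place does in this assay, so the expectation rests on one number alone. The estimated step, a 2.1-fold lower number from compound 2 to compound 3 (0.33 log units; beyond the scatter), is modest and points towards stronger inhibition, and a report without a number remains possible. Compound 3 is expected at 80000 nM, with an estimated range from 20000 nM to 250000 nM.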

Compound 3, half-maximal inhibitory concentration: 191000 nM
Estimate against measurement, compound 3: 2.4-fold (0.38 log units) below, within the range that was stated.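

Among these compounds, the exchange at this aromatic nitrogen gives the first measured step at this position: in this assay it amounts to a 1.1-fold higher number from compound 2 to compound 3 (0.05 log units; within the scatter) for pentyl in place of 4-acetylphenyl. The six-membered aromatic ring of carbon only and the hydrogen-bond acceptor both leave with that group, and a chain with no ring enters, yet the two numbers stay within the scatter of each other, so in this one pair the ring is not needed to keep the number where it stands. Nothing available here accounts for this result.

Compound 1, reported without a number, cannot be placed on this scale. Going by these compounds, it remains open whether a carboxylic acid, a primary amine or a longer chain on this nitrogen would move the number beyond the scatter.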